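A few compounds are considered here, and "the series" means these few. Any claim that something is new, unique, unknown or untested is made for them only; others in the source may bear on it.

Compound 1 `CCCCCCCCNC1=CC(=O)C(C(C)(C)C)=CC1=O` sits at the limit of an ADME assay on HaCaT cells (Homo sapiens) for cytotoxicity, read by MTT assay, with a stated time of 72 h (a higher number here means a weaker inhibitor, a lower number a stronger inhibitor), > 100000 nM, and so returns no number. Compound 2 `CNC1=CC(=O)C(C(C)(C)C)=CC1=O` gives 28000 nM in this assay, the highest of the two numbers in hand; compound 3 `CCCCNC1=CC(=O)C=C(C(C)(C)C)C1=O` gives 11000 nM. Going by the values given here, the only measured step at the chain carbon bound to the amine nitrogen is an at least 3.5-fold lower number from compound 1 to compound 2 (0.55 log units; beyond the scatter), so the shorter chain went with the lower number. Compound 4 `CC(C)(C)C1=CC(=O)C(NCc2ccccc2)=CC1=O` differs from compound 2 by phenyl in place of hydrogen on a saturated chain carbon bound to an amine nitrogen. Phenyl enters at the place where removing heptyl once lowered the number, so the step of a 1.4-fold higher number from compound 2 to compound 4 (0.15 log units; within the scatter) is expected to run back toward a higher number, modest in size and possibly within the scatter. Compound 4 is estimated at 40000 nM, between 12000 nM and 120000 nM.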

Compound 4, half-maximal inhibitory concentration: 28000 nM
Estimate against measurement, compound 4: 1.4-fold (0.15 log units) above; low and high end bracket the measured number.
By their numbers in this assay, from the lowest: compound 3; then compounds 2 and 4 (each within the scatter of the next). At a limit, above all of these: compound 1.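

On the saturated chain carbon bound to an amine nitrogen, phenyl in place of hydrogen gives no change at the digits printed from compound 2 to compound 4 (within the scatter), so this place takes an aromatic ring without a step that can be read as a change. Phenyl in place of heptyl gives an at least 3.5-fold lower number from compound 1 to compound 4 (0.55 log units; beyond the scatter), so the heptyl compound stays apart from both compound 2 and compound 4. Compound 1 stands at a limit, not a number: the limit of > 100000 nM in this assay, at which 1 of the 4 values shown sits.

Still open, from the compounds shown here alone, is whether a carboxylic acid or an amine on the phenyl ring would move the number. Also open, going by these compounds, is whether a longer chain ending in phenyl would follow compound 4 or compound 1.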